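The source may hold more compounds than are shown below. What is called first, only, known or untested is meant among the compounds shown, and "the series" means these compounds.

Compound 3 `COc1cc(-c2nn(-c3cccc(NC(=O)Nc4ccc(Cl)c(C(F)(F)F)c4)c3)cc2-c2ccncc2)ccc1Cl` carries a 4-chloro-3-(trifluoromethyl)phenyl on the urea; in a functional assay on NCI-H460 cells (Homo sapiens) for inhibition, read by sulforhodamine B assay, with a stated time of 48 h (on this read-out lower numbers stand for stronger inhibition of growth and higher numbers for weaker inhibition of growth), compound 3 gives 1110 nM, the highest of the three numbers here, though its gaps to compound 1 and compound 2 both sit within the scatter. Compound 2 `COc1cc(-c2nn(-c3cccc(NC(=O)Nc4cccc(C(F)(F)F)c4)c3)cc2-c2ccncc2)ccc1Cl`, which lacks the chloro on that ring, gives 763 nM in this assay; the step of a 1.5-fold higher number from compound 2 to compound 3 (0.16 log units; within the scatter) shows that this chloro changed little. Compound 1 `O=C(Nc1cccc(-n2cc(-c3ccncc3)c(-c3ccc(Cl)c(O)c3)n2)c1)Nc1ccc(Cl)c(Cl)c1` is a 3,4-dichlorophenyl urea whose other aryl bears a hydroxy where compounds 2 and 3 bear a methoxy; in this assay compound 1 gives 993 nM.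

Compound 4 `COc1cc(-c2nn(-c3cccc(NC(=O)Nc4ccc(Cl)c(Cl)c4)c3)cc2-c2ccncc2)ccc1Cl` differs from compound 3 by chloro in place of trifluoromethyl on an aromatic carbon. For the measured compounds named here, no measured step in this set exchanges a trifluoromethyl for a chloro. What bears on it: the step of a 1.5-fold higher number from compound 2 to compound 3 (0.16 log units; within the scatter) stayed within the scatter, and compound 1, the only measured 3,4-dichlorophenyl urea, gives 993 nM, while compound 3 gives 1110 nM. Hence the expected step is a 1.1-fold lower number from compound 3 to compound 4 (0.05 log units; within the scatter), not beyond the scatter. Compound 4 is estimated at 1000 nM in this assay, with a range from 450 nM to 2300 nM.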

Compound 4, concentration for 50% growth inhibition: 1110 nM
Beside the measured number, compound 4's estimate is 1.1-fold (0.05 log units) below it; the range from low to high includes it.
By their numbers in this assay, from the lowest: compounds 2, 1, 3 and 4 (each within the scatter of the next).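

In this assay, for the compounds shown here, the first measured change at this position, on an aromatic carbon ortho to a chloro group, is the exchange of trifluoromethyl for chloro, and it leaves the read-out in place (no change at the digits printed from compound 3 to compound 4 (within the scatter)). The same compound 4 also links the two other ends of the set: the change from 3-(trifluoromethyl)phenyl to 3,4-dichlorophenyl on the urea nitrogen stays within the scatter (a 1.5-fold higher number from compound 2 to compound 4 (0.16 log units; within the scatter)), as does methyl in place of hydrogen on the oxygen of the other aryl (a 1.1-fold higher number from compound 1 to compound 4 (0.05 log units; within the scatter)), so neither of these changes separates the compounds in this growth read-out. No supporting data are available to explain why these changes make so little difference.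

Still open, from the compounds shown here alone, is whether a group of another kind at this position, such as an amine, a carboxylic acid or a longer alkyl chain, would give a step beyond the scatter. Also open, going by these compounds, is whether a larger group on the oxygen, such as ethyl or benzyl, would stay as close to the methyl and hydrogen pair.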